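Cytotoxicity notes on two amides and a polar analogue

A few compounds are considered here, and "the series" means these few. Any claim that something is new, unique, unknown or untested is made for them only; others in the source may bear on it.

Measured so far:
compound 1, `Cc1cc(C)cc(NC(=O)COc2cc(C)nc3ccc(Cl)cc23)c1`: > 100000 nM
compound 2, `COc1ccc2nc(C)cc(OCC(=O)Nc3cccc(C)c3)c2c1`: 39800 nM

In a toxicity assay on HepG2 cells (Homo sapiens) for inhibition, read by CellTiter-Glo, with a stated time of 48 h (on this read-out lower numbers stand for stronger inhibition and higher numbers for weaker inhibition), compound 1 gives only a limit, > 100000 nM. Compound 2 gives 39800 nM in this assay, the only number shown in the series. The other value shown is the limit of > 100000 nM in this assay, at which 1 of the 2 values shown sits. Compound 3, `COc1ccc2nc(C)cc(OCC(=O)NC3CONC3=O)c2c1`, carries a group of 6 heavy atoms (3 carbon, 1 nitrogen, 2 oxygen; one five-membered non-aromatic ring with 2 hetero atoms) in place of a group of 7 heavy atoms (7 carbon; one six-membered aromatic ring of carbon only), on an amide-type nitrogen. Among the compounds with values here, no step between measured compounds is at hand; the expected step of a 2.0-fold higher number from compound 2 to compound 3 (0.30 log units; within the scatter) is toward weaker inhibition, moderate in size and probably beyond the scatter. Compound 3 is expected at 80000 nM in this assay, within 30000 nM to 200000 nM, with a fair chance that only a limit is reported.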

Compound 3, half-maximal inhibitory concentration: > 100000 nM
Compound 3 was reported as a limit (the forecaster's own chance of this, stated with the estimate: 55%); middle value at least 1.2-fold (0.09 log units) from the limit.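

In this assay, the five-membered non-aromatic ring in place of 3-methylphenyl on the amide-type nitrogen gives an at least 2.5-fold higher number from compound 2 to compound 3 (0.40 log units; beyond the scatter), the first step read at this position. Compound 3 gives a limit and not a number, so the step has no upper bound, and the series now gathers there: the limit of > 100000 nM in this assay, at which 2 of the 3 values shown sit.

From the compounds shown here alone, whether the step follows the loss of the aromatic ring or the entry of the hydrogen-bond donor and acceptors stays open. A cyclohexyl group on the same nitrogen would separate these two changes, and a carboxylic acid or an amine there remains untested in the compounds shown.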